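Changing the aryl group on the ring nitrogen

The compounds below may be only part of what the source reports. "The series", "measured", "known", "first", "only" and "open" are said of these compounds alone.

Three close analogues have been tested in a functional assay on U-87MG ATCC cells for antiproliferative activity against U-87 MG (Homo sapiens), read by MTT assay, with a stated time of 72 h; on this read-out higher numbers stand for weaker inhibition and lower numbers for stronger inhibition. Compound 1 `CNC(=O)c1cc(Oc2ccc(NC(=O)c3cc4cccnc4n(-c4ccccc4)c3=O)cc2)ccn1` gives 1820 nM, compound 2 `CNC(=O)c1cc(Oc2ccc(NC(=O)c3cc4cccnc4n(-c4ccccc4F)c3=O)cc2)ccn1` gives 3360 nM, and compound 3 `CNC(=O)c1cc(Oc2ccc(NC(=O)c3cc4cccnc4n(-c4ccc(F)cc4)c3=O)cc2)ccn1` gives 2910 nM. Compound 2 carries the highest of the three numbers, though every gap is small: a 1.8-fold higher number from compound 1 to compound 2 (0.27 log units; within the scatter), a 1.6-fold higher number from compound 1 to compound 3 (0.20 log units; within the scatter), and a 1.2-fold lower number from compound 2 to compound 3 (0.06 log units; within the scatter). Compound 4 `CNC(=O)c1cc(Oc2ccc(NC(=O)c3cc4cccnc4n(-c4ccc(C(F)(F)F)cc4Cl)c3=O)cc2)ccn1` has not yet been measured; it differs from compound 2 only in that (2-chloro-4-(trifluoromethyl)phenyl in place of 2-fluorophenyl on an aromatic nitrogen). Among the measured compounds shown here, the steps that bear on this change, each altering the phenyl ring on that aromatic nitrogen, stayed within the scatter, so no step beyond the scatter is expected in this assay, even though the entering group is larger than anything tried so far. Compound 4 is therefore expected to give 3000 nM, within a range from 1000 nM to 9000 nM. This estimate amounts to a 1.1-fold lower number from compound 2 to compound 4 (0.05 log units; within the scatter).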

Compound 4, half-maximal inhibitory concentration: 19800 nM
Compound 4: middle estimate off by 6.6-fold (0.82 log units), on the low side, and the stated range ends below it.
By their numbers in this assay, from the lowest: compounds 1, 3 and 2 (each within the scatter of the next); then compound 4.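

In this assay, among the compounds shown here, this position on the aromatic nitrogen proves sensitive to the group it carries: 2-chloro-4-(trifluoromethyl)phenyl gives a 5.9-fold higher number from compound 2 to compound 4 (0.77 log units; beyond the scatter) and a 6.8-fold higher number from compound 3 to compound 4 (0.83 log units; beyond the scatter) and also an 11-fold higher number from compound 1 to compound 4 (1.04 log units; beyond the scatter) as the first steps here beyond the scatter. For the compounds shown here, a single fluoro on the phenyl ring had produced no such step, so this position accepts some changes but not all. No measured evidence here explains the weaker inhibition. The chloro and trifluoromethyl groups enter only together, leaving their separate contributions open, as well as the outcome with an amine or a carboxylic acid on this ring.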